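Removing One Chloro From the Benzyl Group

The source may hold more compounds than are shown below. What is called first, only, known or untested is meant among the compounds shown, and "the series" means these compounds.

Compound 1, `Cc1ccc(Cn2cc(/C=N/NC(=O)Nc3nc4ccc(CN(C)C)cc4s3)c3ccccc32)cc1`: 200 nM
Compound 2, `CN(C)Cc1ccc2nc(NC(=O)N/N=C/c3cn(Cc4ccccc4)c4ccccc34)sc2c1`: 400 nM
Compound 3, `CN(C)Cc1ccc2nc(NC(=O)N/N=C/c3cn(Cc4ccc(Cl)cc4Cl)c4ccccc34)sc2c1`: 950 nM

In a functional assay on NCI-H460 cells (Homo sapiens) for cytotoxicity, read by MTT assay, with a stated time of 72 h (a higher number here means a weaker inhibitor, a lower number a stronger inhibitor), compound 3 gives the highest number of the three, beyond the scatter from both compound 2 and compound 1. Compound 4, `CN(C)Cc1ccc2nc(NC(=O)N/N=C/c3cn(Cc4ccc(Cl)cc4)c4ccccc34)sc2c1`, differs from compound 3 by hydrogen in place of chloro on an aromatic carbon. Within the data shown here, the steps that bear on this are a 2.4-fold higher number from compound 2 to compound 3 (0.38 log units; beyond the scatter) and a 4.8-fold higher number from compound 1 to compound 3 (0.68 log units; beyond the scatter); compound 4 sits between compound 2 and compound 3 in structure, keeping one chloro and losing the other. The author therefore expects a modest step downward in this assay, a 1.7-fold lower number from compound 3 to compound 4 (0.24 log units; within the scatter), toward the number of compound 2. Compound 4 is estimated at 550 nM, with a range from 300 nM to 1100 nM.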

Compound 4, half-maximal inhibitory concentration: 290 nM
Compound 4: middle estimate off by 1.9-fold (0.28 log units), on the high side; the measured number lies below the stated range.
By their numbers in this assay, from the lowest: compounds 1, 4 and 2 (each within the scatter of the next); then compound 3.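

In this assay the higher number of the 2,4-dichlorobenzyl pattern traces to the chloro ortho to a large group, and removing that chloro alone gives a step beyond the scatter (a 3.3-fold lower number from compound 3 to compound 4 (0.52 log units; beyond the scatter)). The 4-chlorobenzyl group, by contrast, cannot be told apart from benzyl (a 1.4-fold lower number from compound 2 to compound 4 (0.14 log units; within the scatter)) or from the 4-methyl counterpart (a 1.5-fold higher number from compound 1 to compound 4 (0.16 log units; within the scatter)). Nothing measured here gives a cause for this. As far as these compounds go, what stays open is whether a fluoro or a methoxy group on that same aromatic carbon would raise the number as chloro does.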